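The source may report more compounds than this note shows. Statements on the series, on what has been measured and on what is new or still open speak of the compounds shown alone.

Measured so far in an ADME assay on MT4 cells (Homo sapiens) for cytotoxicity, read by MTT assay; a higher number here means that more compound is tolerated, a lower number that less compound is tolerated:
- compound 1 `CCOC(=O)/C(O)=C/C(=O)c1cn(Cc2cc(F)c(F)c(F)c2)c2cccc(OC)c12`: 33400 nM
- compound 2 `COc1cccc2c1c(C(=O)/C=C(\O)C(=O)O)cn2Cc1cc(F)ccc1F`: 46200 nM
- compound 3 `COc1cccc2c1c(C(=O)/C=C(\O)C(=O)O)cn2Cc1cccc(F)c1F`: 17500 nM

Compound 1 stands second highest of the three numbers in this assay; its nearest neighbour is compound 2, within the scatter, and its furthest is compound 3, also within the scatter. For the measured compounds named here, the only step between measured compounds that differ in one place is a 2.6-fold lower number from compound 2 to compound 3 (0.42 log units; beyond the scatter), a modest step that swaps one difluorophenyl for another on the saturated chain carbon bound to the aromatic nitrogen.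

Compound 4 `CCOC(=O)/C(O)=C/C(=O)c1cn(Cc2cccc(F)c2)c2cccc(OC)c12` is not yet measured in this assay. The change from compound 1 is 3-fluorophenyl in place of 3,4,5-trifluorophenyl on a saturated chain carbon bound to an aromatic nitrogen. Going by the values given here, no measured step removes fluorines from this ring, so the step from compound 2 to compound 3 bears on it only as a sign that changes on this ring have so far stayed modest. The three measured numbers span a narrow band, and compound 4 is expected to fall within it, with a 1.0-fold higher number from compound 1 to compound 4 (0.02 log units; within the scatter) expected to lie within the scatter. The estimate for compound 4 in this assay is 35000 nM, with a range from 15000 nM to 80000 nM.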

Compound 4, half-maximal cytotoxic concentration: 63200 nM
The estimate for compound 4 lay 1.8-fold (0.26 log units) below the measured number; measured number inside the range.
By their numbers in this assay, from the lowest: compounds 3, 1, 2 and 4 (each within the scatter of the next, the first and the last beyond it).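

In this assay, a 1.9-fold higher number from compound 1 to compound 4 (0.28 log units; within the scatter) is the first step shown that takes fluorines off this ring, and it stays within the scatter. For the compounds shown here, at this place on the saturated chain carbon bound to the aromatic nitrogen, the ethyl ester pair therefore gives no readable difference between 3,4,5-trifluorobenzyl and 3-fluorobenzyl, while the one step beyond the scatter remains a 2.6-fold lower number from compound 2 to compound 3 (0.42 log units; beyond the scatter), which keeps the fluorine count and moves the fluorines. No measured information accounts for either step.

The compounds shown carry only fluorines on this ring, so it stays open whether a chlorine, a methoxy group or an amine there would give a step beyond the scatter. Also open, as far as these compounds go, is whether a carboxylic acid in place of the ethyl ester of compound 4 would change its number.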